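Ring contraction on the biaryl core: compound 1 to compound 4

The source may hold more compounds than are shown below. What is called first, only, known or untested is meant among the compounds shown, and "the series" means these compounds.

Three compounds of the series have numbers in an ADME assay on MT4 cells (Homo sapiens) for cytotoxicity, read by MTT assay, with a stated time of 4 days; on this read-out higher numbers stand for lower toxicity in this test and lower numbers for higher toxicity in this test. Compound 1 `Cc1ccc(-c2c(C)c(-c3ccc4c(c3C)CCCO4)c(C(OC(C)(C)C)C(=O)O)c(C)c2NS(C)(=O)=O)cc1C` gives 24000 nM and holds the highest of the three numbers. Compound 2 `CC(=O)Nc1c(C)c(C(OC(C)(C)C)C(=O)O)c(-c2ccc(C)c(C)c2)c(C)c1-c1ccc(C)c(C)c1` gives 19000 nM, a number within the scatter of compound 1. Among the measured compounds shown here, compound 3 `Cc1ccc(-c2c(C)c(-c3ccc(C)c(C)c3)c(C(OC(C)(C)C)C(=O)O)c(C)c2NS(=O)(=O)c2ccccc2)cc1C` gives 11000 nM, the only number beyond the scatter from compound 1. For the measured compounds named here, the single one-place step measured so far, a 1.7-fold lower number from compound 2 to compound 3 (0.24 log units; within the scatter), concerns the substituent on the ring nitrogen and lies within the scatter.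

Compound 4 `Cc1ccc(-c2c(C)c(-c3ccc4c(c3)CCO4)c(C(OC(C)(C)C)C(=O)O)c(C)c2NS(C)(=O)=O)cc1C` differs from compound 1 at another site: a group of 9 heavy atoms (8 carbon, 1 oxygen; one five-membered non-aromatic ring with 1 hetero atom, one six-membered aromatic ring of carbon only) in place of a group of 11 heavy atoms (10 carbon, 1 oxygen; one six-membered non-aromatic ring with 1 hetero atom, one six-membered aromatic ring of carbon only), on an aromatic carbon. The six-membered non-aromatic ring of the leaving group becomes a five-membered non-aromatic ring in the entering group; the site on the aromatic carbon is unchanged. Going by the values given here, no measured step touches this position, and the only step known, from an acetyl to a phenylsulfonyl on the nitrogen, is itself within the scatter. The step of no change at the digits printed from compound 1 to compound 4 (within the scatter) is therefore expected to stay within the scatter. Compound 4 is expected to give 24000 nM, with a range from 12000 nM to 48000 nM.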

Compound 4, half-maximal cytotoxic concentration: 38000 nM
For compound 4 the middle estimate is 1.6-fold (0.20 log units) below the measured one; the measured number falls inside the stated range.
By their numbers in this assay, from the lowest: compounds 3, 2, 1 and 4 (each within the scatter of the next, the first and the last beyond it).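

Among the compounds shown here, at the aromatic carbon para to the methanesulfonamido group, the step of a 1.6-fold higher number from compound 1 to compound 4 (0.20 log units; within the scatter) gives the first reading of this position in this assay, and it stays within the scatter. The group entering here differs in more than ring size: the five-membered non-aromatic ring replaces the six-membered one, and the methyl group on the aromatic ring of the leaving group is also absent, so this single step cannot separate the two changes. No measured evidence bears on the origin of this result.

The compounds shown leave open how the ring change alone would read, with that methyl group kept on the aromatic ring. They also leave open whether an amine or a carboxylic acid on this aromatic ring would stay within the scatter of compound 1.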